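A few compounds are considered here, and "the series" means these few. Any claim that something is new, unique, unknown or untested is made for them only; others in the source may bear on it.

Measured compounds:

Compound 1, `O=C(NC(=S)N1CCN(c2ccccc2)CC1)c1ccc([N+](=O)[O-])cc1`: 76.6%
Compound 2, `COc1ccc(C(=O)NC(=S)N2CCN(c3ccccc3)CC2)cc1`: 36.8%
Compound 3, `COc1ccc(C(=O)NC(=S)N(c2ccccc2)c2ccccc2)cc1`: 19.2%

All three were tested in an assay for inhibition of Polyunsaturated fatty acid 5-lipoxygenase (Homo sapiens), read by spectrophotometry, tested at 10 uM; on this read-out higher numbers stand for more inhibition at the one concentration tested (going by the name of the read-out) and lower numbers for less inhibition. Compound 1 and compound 2 share one core, and within that core a single change is made: nitro in place of methoxy on an aromatic carbon. This change brings a step of a number 39.8 percentage points higher from compound 2 to compound 1 (beyond the scatter). Compound 3 has a different core; how the core of compound 3 differs from the core of compound 2 is not broken down here. In this assay compound 3 gives the lowest of the three numbers, and its gaps to compound 2 and to compound 1 both lie beyond the usual scatter.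

Compound 4, `O=C(NC(=S)N(c1ccccc1)c1ccccc1)c1ccc([N+](=O)[O-])cc1`, has not yet been measured in this assay. It is built on the core of compound 3 with the same change that turns compound 2 into compound 1: nitro in place of methoxy on an aromatic carbon. The place of the change is described in the same words for both pairs, so it counts as the same change. It is expected that compound 4 will stand higher than compound 3 in this assay, with a step of about a number 30.8 percentage points higher from compound 3 to compound 4 (beyond the scatter), an expectation resting on the size of the step from compound 2 to compound 1, a number 39.8 percentage points higher from compound 2 to compound 1 (beyond the scatter), though it is seen only once and on a different core. Compound 4 is therefore estimated at 50%, within a range from 28% to 72%.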

Compound 4, a percentage reported as inhibition, at one concentration (the size of the read-out at that concentration, not a potency): 30.9%
Estimate against measurement, compound 4: 19.1 percentage points above, and the stated range covers the measured number.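

In this assay, replacing methoxy with nitro again moves the number upward on the second core, with a number 11.7 percentage points higher from compound 3 to compound 4 (beyond the scatter). The direction of the change therefore carries over between these two cores, but its size does not: the same change on two cores in this assay, a number 39.8 percentage points higher (beyond the scatter) from compound 2 to compound 1 and a number 11.7 percentage points higher (beyond the scatter) from compound 3 to compound 4, 28.1 percentage points apart, beyond the scatter of two such steps Two pairs give no reason for the smaller step and no rule for any further core, so a step read on one core can hint at the direction on another here, but it cannot simply be added on as a fixed amount.

The compounds shown leave open whether other groups in the place of the methoxy, such as a chlorine atom, an amine or a carboxylic acid, would also give different step sizes on these two cores. They also leave open how the swap from 4-methoxyphenyl to 4-nitrophenyl behaves on a third core, and whether the order seen at the one concentration tested would hold in a full potency measurement.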